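From Pyridin-2-yl to 3-(Trifluoromethoxy)phenyl

The compounds below may be only part of what the source reports. "The series", "measured", "known", "first", "only" and "open" are said of these compounds alone.

Three related compounds have been tested so far in an ADME assay on MRC5 cells (Homo sapiens) for cytotoxicity, read by fluorescence and resazurin assay, with a stated time of 3 days; on this read-out higher numbers stand for weaker inhibition and lower numbers for stronger inhibition. Compound 1 (`Cc1cccc(Oc2cccc(CN3CCC(n4cc(C)c(=O)[nH]c4=O)CC3)c2)c1`) gives > 64000 nM, which is a limit of the assay and not a number. Compound 2 (`Cc1cn(C2CCN(Cc3cccc(Oc4ccc(F)c(F)c4)c3)CC2)c(=O)[nH]c1=O`) gives > 64000 nM, again a limit. Compound 3 (`Cc1cn(C2CCN(Cc3cccc(Oc4ccccn4)c3)CC2)c(=O)[nH]c1=O`) gives > 64000 nM, also a limit. Compound 3 therefore has no measured number and stands with the other two at the limit of > 64000 nM in this assay, at which 3 of the 3 values shown sit.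

Compound 4 (`Cc1cn(C2CCN(Cc3cccc(Oc4cccc(OC(F)(F)F)c4)c3)CC2)c(=O)[nH]c1=O`) carries 3-(trifluoromethoxy)phenyl in place of pyridin-2-yl on an oxygen on an aromatic ring. Three measured exchanges at this same place bear on the change: a step that the two limits leave unreadable from compound 1 to compound 2, a step that the two limits leave unreadable from compound 1 to compound 3 and a step that the two limits leave unreadable from compound 2 to compound 3. None of them has a readable size, so they show no measured effect in either direction. The closest is a step that the two limits leave unreadable from compound 1 to compound 3, where 3-methylphenyl gives way to pyridin-2-yl, roughly the reverse of the new exchange. With no readable step to build on, no change beyond the scatter is expected in this assay, and compound 4 will most likely stay at the limit. The expected change is an at least 1.0-fold lower number from compound 3 to compound 4 (0.02 log units; that floor lies within the scatter). For compound 4 the estimated value is 60000 nM, with an expected range from 25000 nM to 64000 nM.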

Compound 4, half-maximal inhibitory concentration: 5260 nM
The estimate for compound 4 lay 11-fold (1.06 log units) above the measured number; the measured number lies below the stated range.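

In this assay, the group on an oxygen on an aromatic ring now proves able to shift the read-out, with an at least 12-fold lower number from compound 3 to compound 4 (1.08 log units; beyond the scatter) when 3-(trifluoromethoxy)phenyl replaces pyridin-2-yl and an at least 12-fold lower number from compound 2 to compound 4 (1.08 log units; beyond the scatter) when it replaces 3,4-difluorophenyl. Even the exchange of a single substituent on the outer ring is enough, as trifluoromethoxy in place of methyl on an aromatic carbon gives an at least 12-fold lower number from compound 1 to compound 4 (1.08 log units; beyond the scatter). The steps among the three earlier compounds cannot be read, and compound 4 is the only one of the series that has a number rather than a limit: the limit of > 64000 nM in this assay, at which 3 of the 4 values shown sit.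

On these data alone, all three new steps are only minimum sizes, so how large the change truly is stays open, and a single compound cannot show whether other substituents would act alike. As far as these compounds go, it also remains open whether a trifluoromethyl, an ethoxy or a chlorine on the same ring, or an amine or a carboxylic acid in that role, would bring the number down in the same way.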